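A few compounds are considered here, and "the series" means these few. Any claim that something is new, unique, unknown or untested is made for them only; others in the source may bear on it.

In a functional assay on K562 cells (Homo sapiens) for cytotoxicity, read by MTT assay, with a stated time of 3 days (a higher number here means a weaker inhibitor, a lower number a stronger inhibitor), compound 1 `N#Cc1c(O)nc(SCc2nc3ccccc3[nH]2)nc1-c1ccccc1` gives 4.63 nM, compound 2 `N#Cc1c(NNC(N)=S)nc(SCc2nc3ccccc3[nH]2)nc1-c1ccccc1` gives 8.9 nM and compound 3 `N#Cc1c(-c2ccccc2)nc(SCc2nc3ccccc3[nH]2)nc1N1CCNCC1` gives 4.38 nM. Compound 3 thus sits level with compound 1, and only just clear of compound 2. Compound 4 `CN1CCN(c2nc(SCc3nc4ccccc4[nH]3)nc(-c3ccccc3)c2C#N)CC1` adds one change to compound 3: methyl in place of hydrogen on an amine nitrogen in a ring. Within the data shown here, no measured step tests this nitrogen. The nearest evidence is the exchange of whole groups on the aromatic carbon: a 1.1-fold lower number from compound 1 to compound 3 (0.02 log units; within the scatter), a 1.9-fold higher number from compound 1 to compound 2 (0.28 log units; within the scatter) and a 2.0-fold lower number from compound 2 to compound 3 (0.31 log units; beyond the scatter). All three steps are small, so no step beyond the scatter is expected, in either direction. The expected result is a 1.1-fold higher number from compound 3 to compound 4 (0.04 log units; within the scatter). For compound 4 the estimate is 4.8 nM, with an expected range of 2.5 nM to 9.5 nM.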

Compound 4, half-maximal inhibitory concentration: 2.4 nM
Beside the measured number, compound 4's estimate is 2.0-fold (0.30 log units) above it, outside the stated range (below it).
By their numbers in this assay, from the lowest: compounds 4, 3, 1 and 2 (each within the scatter of the next, the first and the last beyond it).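

Among these compounds, this is the first direct test of the amine nitrogen in the ring: in this assay, the change from piperazin-1-yl to 4-methylpiperazin-1-yl gives a 1.8-fold lower number from compound 3 to compound 4 (0.26 log units; within the scatter) and so the methyl is tolerated at this position. The 4-methylpiperazin-1-yl group also stays level with hydroxy, with a 1.9-fold lower number from compound 1 to compound 4 (0.29 log units; within the scatter) on that exchange, and it separates from the group in compound 2 with a 3.7-fold lower number from compound 2 to compound 4 (0.57 log units; beyond the scatter) on that one. Nothing measured here explains this result. As far as these compounds go, whether an ethyl group, a longer chain or an acetyl group on this nitrogen would keep the number in this range stays open. So does the effect of a carboxylic acid on the chain that ends this group.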